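A Difluorophenyl Replacement at the Carbonyl Carbon

This account rests on a few compounds, and the source may have more. Where it says the series, first, only, none or still open, it means among the compounds named here.

Three compounds have been measured in a functional assay on SK-MEL-2 cells (Homo sapiens) for inhibition, read by sulforhodamine B assay, with a stated time of 48 h; on this read-out higher numbers stand for lower toxicity in this test and lower numbers for higher toxicity in this test:

Compound 1, `COc1cc(-c2cc(/C=C/C(=O)c3ccc(N)cc3)[nH]n2)cc(OC)c1OC`: 31900 nM
Compound 2, `COc1cc(-c2cc(/C=C/C(=O)c3ccc(Cl)c(Cl)c3)[nH]n2)cc(OC)c1OC`: 83800 nM
Compound 3, `COc1ccc(C(=O)/C=C/c2cc(-c3cc(OC)c(OC)c(OC)c3)n[nH]2)cc1`: 99200 nM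

Compound 3 gives the highest of the three numbers in this assay. Its nearest neighbour is compound 2, since a 1.2-fold higher number from compound 2 to compound 3 (0.07 log units; within the scatter); its furthest is compound 1, since a 3.1-fold higher number from compound 1 to compound 3 (0.49 log units; beyond the scatter). Compound 4, `COc1cc(-c2cc(/C=C/C(=O)c3ccc(F)c(F)c3)[nH]n2)cc(OC)c1OC`, has not been measured. It differs from compound 3 in one place: 3,4-difluorophenyl in place of 4-methoxyphenyl on a carbonyl carbon.

Among the measured compounds shown here, two measured steps bear on this. The step from compound 2 to compound 3 exchanges a dihalogenated phenyl for the 4-methoxyphenyl on the same carbonyl carbon, and it gave a 1.2-fold higher number from compound 2 to compound 3 (0.07 log units; within the scatter). The step from compound 1 to compound 2 put the 3,4-dichlorophenyl in for the 4-aminophenyl and gave a 2.6-fold higher number from compound 1 to compound 2 (0.42 log units; beyond the scatter). Going back from 4-methoxyphenyl to a dihalogenated ring, now with fluorine, is therefore expected to give no step beyond the scatter, so that a 1.1-fold lower number from compound 3 to compound 4 (0.04 log units; within the scatter) is the estimated change. Compound 4 is expected at 90000 nM in this assay, within a range from 40000 nM to 200000 nM.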

Compound 4, concentration lethal to 50% of the cells: 41100 nM
The estimate for compound 4 lay 2.2-fold (0.34 log units) above the measured number, within the range that was stated.
By their numbers in this assay, from the lowest: compounds 1 and 4 (each within the scatter of the next); then compounds 2 and 3 (each within the scatter of the next).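

In this assay, the exchange of halogen on the ring at the carbonyl carbon is not silent: 3,4-difluorophenyl in place of 3,4-dichlorophenyl gave a 2.0-fold lower number from compound 2 to compound 4 (0.31 log units; beyond the scatter), and 3,4-difluorophenyl in place of 4-methoxyphenyl gave a 2.4-fold lower number from compound 3 to compound 4 (0.38 log units; beyond the scatter), so the match between the dichlorinated and methoxylated rings does not extend to every dihalogenated ring. The 3,4-difluorophenyl ring instead falls with the 4-aminophenyl ring, at a 1.3-fold higher number from compound 1 to compound 4 (0.11 log units; within the scatter). No measurement at hand accounts for this difference between the two dihalogenated rings.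

The compounds shown leave open how an unsubstituted phenyl ring, a carboxylic acid or a dimethylamino group on that ring would read in this test. They also leave open whether the gap between the difluorinated and dichlorinated rings would persist on a core without the trimethoxyphenyl group.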